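Benzoyl gives way to ethylcarbamoyl on the shared core

The compounds below may be only part of what the source reports. "The series", "measured", "known", "first", "only" and "open" are said of these compounds alone.

In a functional assay on HEL cells (Homo sapiens) (on this read-out lower numbers stand for higher toxicity in this test and higher numbers for lower toxicity in this test), compound 3 (`Cc1cn([C@@H]2O[C@H](CO[Si](C)(C)C(C)(C)C)[C@@]3(OS(=O)(=O)C=C3NC(=O)c3ccccc3)[C@H]2O[Si](C)(C)C(C)(C)C)c(=O)n(C)c1=O`) gives 9700 nM and sits within the scatter of compound 2 (`CCOC(=O)CNC(=O)NC1=CS(=O)(=O)O[C@@]12[C@@H](CO[Si](C)(C)C(C)(C)C)O[C@@H](n1cc(C)c(=O)n(C)c1=O)[C@@H]2O[Si](C)(C)C(C)(C)C`) at 13000 nM while compound 1 (`Cc1cn([C@@H]2O[C@H](CO[Si](C)(C)C(C)(C)C)[C@@]3(OS(=O)(=O)C=C3NCC(=O)C(=O)N3CCC3)[C@H]2O[Si](C)(C)C(C)(C)C)c(=O)n(C)c1=O`) stands well higher at 84400 nM on this scale. Compound 4 (`CCNC(=O)NC1=CS(=O)(=O)O[C@@]12[C@@H](CO[Si](C)(C)C(C)(C)C)O[C@@H](n1cc(C)c(=O)n(C)c1=O)[C@@H]2O[Si](C)(C)C(C)(C)C`) carries ethylamino in place of phenyl on a carbonyl carbon. The closest guide changes that same place: a 1.3-fold lower number from compound 2 to compound 3 (0.13 log units; within the scatter) puts phenyl in place of ((ethoxycarbonyl)methyl)amino and stays within the scatter. The larger steps of a 6.5-fold lower number from compound 1 to compound 2 (0.81 log units; beyond the scatter) and an 8.7-fold lower number from compound 1 to compound 3 (0.94 log units; beyond the scatter) both leave the group of compound 1 and bear on this change less directly. No step beyond the scatter is expected in this assay (a 1.2-fold higher number from compound 3 to compound 4 (0.09 log units; within the scatter)). For compound 4 the estimated value is 12000 nM (expected range 5000 nM to 35000 nM).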

Compound 4, half-maximal cytotoxic concentration: 10000 nM
Compound 4: the middle estimate sits 1.2-fold (0.08 log units) above what was measured; low and high end bracket the measured number.
By their numbers in this assay, from the lowest: compounds 3, 4 and 2 (each within the scatter of the next); then compound 1.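

In this assay, ethylamino on the carbonyl carbon and phenyl there give numbers within the scatter of each other (a 1.0-fold higher number from compound 3 to compound 4 (0.01 log units; within the scatter)), and methyl in place of ethoxycarbonyl on the chain also stays within it (a 1.3-fold lower number from compound 2 to compound 4 (0.11 log units; within the scatter)). So neither the aromatic ring nor the ester is needed to hold this level among these compounds, while the distance from compound 1 remains beyond the scatter (an 8.4-fold lower number from compound 1 to compound 4 (0.93 log units; beyond the scatter)). No evidence is available that accounts for these results.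

Going by these compounds, whether a carboxylic acid in place of the ethoxycarbonyl, or a longer chain such as butylamino on the carbonyl carbon, would stay in this group remains open.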